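A few compounds are considered here, and "the series" means these few. Any claim that something is new, unique, unknown or untested is made for them only; others in the source may bear on it.

Compound 1 `COc1ccc(S(=O)(=O)Nc2ccc(-c3nc4ccccc4o3)cc2)cc1` is one of three measured members of this sulfonamide series. In an assay on isolated protein for inhibition of malate dehydrogenase, mitochondrial (Sus scrofa), with stated times of 45 min and 30 min (a higher number here means a weaker inhibitor, a lower number a stronger inhibitor), compound 1 gives > 63000 nM, which is a limit of the assay rather than a number. Compound 2 `O=S(=O)(Nc1ccc2oc(-c3ccccc3)nc2c1)c1cccc(F)c1` likewise gives > 63000 nM in this assay, again a limit. Compound 3 `COc1ccccc1S(=O)(=O)Nc1ccc2oc(-c3ccccc3)nc2c1` gives > 63000 nM, also a limit. For the measured compounds named here, the only single-point change among the measured compounds is a step that the two limits leave unreadable from compound 2 to compound 3, so no readable step exists in the set; the whole picture is the limit of > 63000 nM in this assay, at which 3 of the 3 values shown sit.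

Compound 4 `O=S(=O)(Nc1ccc(-c2nc3ccccc3o2)cc1)c1ccc(Cl)c(Cl)c1` differs from compound 1 by 3,4-dichlorophenyl in place of 4-methoxyphenyl on a sulfonyl sulfur. Going by the values given here, no measured step bears on a change of this kind, and nothing gives a direction or size for it. The expectation is therefore that compound 4 sits where compound 1 does, with the step of a number no higher from compound 1 to compound 4 (the limit leaves the size open) expected to lie within the scatter. The estimate for compound 4 in this assay is 63000 nM, with a range from 20000 nM to 200000 nM, and most likely the assay reports only a limit again.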

Compound 4, half-maximal inhibitory concentration: > 63000 nM
Compound 4 gave a limit, no number; the forecaster's own chance of this, stated with the estimate: 75%; the middle value sits exactly at the limit.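

Compound 1 and compound 4 both give only limits in this assay, so no new step can be read between them. The series stays at one reading: the limit of > 63000 nM in this assay, at which 4 of the 4 values shown sit. The compounds shown leave open which change to the shared core or sulfonyl-bound ring would give a measurable value.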